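This account rests on a few compounds, and the source may have more. Where it says the series, first, only, none or still open, it means among the compounds named here.

In a toxicity assay on NIH3T3 cells (Mus musculus) for cytotoxicity, read by resazurin assay (on this read-out lower numbers stand for an effect already at smaller amounts and higher numbers for an effect only at larger amounts of compound), compound 1 (`CC(C)c1ccc(Cn2cncc2CNc2ccc(-c3nc4ccccc4s3)c(-c3ccccc3)c2)cc1`) gives > 1000 nM, which is a limit of the assay and not a number. Compound 2 (`CCc1ccc(Cn2cncc2CNc2ccc(-c3nc4ccccc4s3)c(-c3ccccc3)c2)cc1`) gives > 1000 nM, which is also a limit. Compound 2 therefore has only a limit to its name, and the evidence so far is the limit of > 1000 nM in this assay, at which 2 of the 2 values shown sit. Compound 3 (`Cc1ccccc1-c1ccc(Cn2cncc2CNc2ccc(-c3nc4ccccc4s3)c(-c3ccccc3)c2)cc1`) carries 2-methylphenyl in place of ethyl on an aromatic carbon, para to a large group: 2-methylphenyl in place of ethyl on an aromatic carbon. Among the measured compounds shown here, the only measured step that bears on this change is a step that the two limits leave unreadable from compound 1 to compound 2, so it offers neither a size nor a direction to carry over. No step beyond the scatter is therefore expected in this assay, and the estimated step is a step that the limit leaves unreadable from compound 2 to compound 3. Compound 3 is expected at about 1500 nM, with an estimated range from 500 nM to 5000 nM.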

Compound 3, half-maximal effective concentration: > 1000 nM
Compound 3: no number, only a limit; the forecaster's own chance of this, stated with the estimate: 75%; the middle value lies beyond the limit too.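

In this assay compound 3 gives > 1000 nM, which is a limit and not a number. Its steps from compound 1 and compound 2 cannot be read, since all three stand at the same limit: the limit of > 1000 nM in this assay, at which 3 of the 3 values shown sit. The compounds shown leave open at what concentration any of them has an effect, and whether isopropyl, ethyl or 2-methylphenyl makes any difference in this assay.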